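Amine substituent swap on the shared core

A few compounds are considered here, and "the series" means these few. Any claim that something is new, unique, unknown or untested is made for them only; others in the source may bear on it.

The series keeps the core of compound 1 `O=C1C(NC2CCCC2)=CC(=O)c2c1nc1n2[C@H]2OC[C@@H](O)[C@H]2OC1` and varies the substituent on the amine nitrogen. In a functional assay on MCF7 cells (Homo sapiens) for inhibition, read by sulforhodamine B assay (a higher number here means a weaker inhibitor, a lower number a stronger inhibitor), compound 1 gives > 16000 nM, which is a limit of the assay and not a number. For the measured compounds named here, the one numbered value in the set belongs to compound 2 `CCOc1ccc(NC2=CC(=O)c3nc4n(c3C2=O)[C@H]2OC[C@@H](O)[C@H]2OC4)cc1`, which in this assay gives 1430 nM. Going by the values given here, compound 1 therefore stands at the weak end of what has been measured, as the limit of > 16000 nM in this assay, at which 1 of the 2 values shown sits, records; no step between measured compounds is available, and the two values show only that compound 2 is measurable where compound 1 is not.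

Compound 3 `O=C1C(NCc2ccccc2)=CC(=O)c2c1nc1n2[C@H]2OC[C@@H](O)[C@H]2OC1` is the next candidate: benzyl in place of cyclopentyl on an amine nitrogen. Whether benzylamino behaves more like cyclopentylamino or more like the substituent of compound 2 is open on these data. The step is expected to be modest and towards stronger inhibition, moving from the limit into the measurable range, at about an at least 2.0-fold lower number from compound 1 to compound 3 (0.30 log units; that floor lies within the scatter) in this assay. Compound 3 is estimated at 8000 nM in this assay, with a range of 2000 nM to 30000 nM, and a fair chance that only a limit is again reported.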

Compound 3, half-maximal inhibitory concentration: > 8000 nM
Compound 3: only a limit was reported; the forecaster's own chance of this, stated with the estimate: 40%; the middle value lies on the limit itself.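

In this assay compound 3 gives > 8000 nM, a limit of the assay and not a number. For the compounds shown here, compound 1 likewise gives only a limit, > 16000 nM, so no step between compound 1 and compound 3 can be read. On these data alone, the size and direction of any change from cyclopentylamino to benzylamino on the shared core remain open.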